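A shorter chain at the edge of the assay

A few compounds are considered here, and "the series" means these few. Any claim that something is new, unique, unknown or untested is made for them only; others in the source may bear on it.

Compound 1 `C=C[C@@](C)(/C=C/c1ccc(OS(=O)(=O)C(F)(F)F)cc1)CCC=C(C)C` gives > 36600 nM as a limit
Compound 2 `C=C[C@@](C)(/C=C/c1ccc(O)cc1)CCC1OC1(C)C` gives > 36600 nM as a limit
Compound 3 `C=C[C@@](C)(/C=C/c1ccc(O)cc1)CCC(O)C(C)(C)O` gives > 36600 nM as a limit

In an ADME assay on BJ cells (Homo sapiens) for cytotoxicity, with a stated time of 72 h (on this read-out lower numbers stand for an effect already at smaller amounts and higher numbers for an effect only at larger amounts of compound), compound 3 stands at > 36600 nM and this is a limit, not a number. Compound 4 `C=C[C@@](C)(/C=C/c1ccc(O)cc1)CCCO` differs from it by hydrogen in place of 1-hydroxy-1-methylethyl on a saturated chain carbon bound to an oxygen on a saturated carbon and a saturated chain carbon and so carries 2-hydroxyethyl where compound 3 carries 2,3-dihydroxy-3-methylbutyl. Among the measured compounds shown here, the one measured step bearing on this part of the chain is a step that the two limits leave unreadable from compound 2 to compound 3 and it offers no size. All that is shown is the limit of > 36600 nM in this assay, at which 3 of the 3 values shown sit, and so no step beyond the scatter is expected in this assay for this change. The expected step is a step that the limit leaves unreadable from compound 3 to compound 4 as an estimate. Compound 4 is expected at about 40000 nM (18000 nM to 80000 nM).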

Compound 4, half-maximal effective concentration: > 36600 nM
Compound 4 was reported as a limit (the forecaster's own chance of this, stated with the estimate: 80%); the middle value is on the limit's open side.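

The steps from compound 3 to compound 4 and from compound 2 to compound 4 cannot be read, as each compares two limits: the limit of > 36600 nM in this assay, at which 4 of the 4 values shown sit.

The compounds shown leave open which change, if any, would give a measurable value in this assay.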